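The source may report more compounds than this note shows. Statements on the series, on what has been measured and on what is new or still open speak of the compounds shown alone.

Measured in a functional assay (Mus musculus) for inhibition, with a stated time of 5 days; a higher number here means a weaker inhibitor, a lower number a stronger inhibitor:
Compound 1, `O=C(O)/C=C/c1cn(-c2ccc(O)cc2)nc1-c1ccc(O)cc1`, gives > 100000 nM, which is a limit of the assay and not a number.
Compound 2, `O=C(O)/C=C/c1cn(-c2ccc(O)cc2)nc1-c1cc(O)ccc1O`, gives > 100000 nM, likewise a limit.
Compound 3, `O=Cc1cn(-c2ccc(O)cc2)nc1-c1ccc(O)cc1`, gives 44000 nM.

Compound 2 differs from compound 1 in its core by 2,5-dihydroxyphenyl in place of 4-hydroxyphenyl on an aromatic carbon. Both sit at the limit of > 100000 nM in this assay, at which 2 of the 3 values shown sit, so the step that the two limits leave unreadable from compound 1 to compound 2 cannot be read. Compound 3 arises from compound 1 by formyl in place of 2-carboxyethenyl on an aromatic carbon, and the step of an at least 2.2-fold lower number from compound 1 to compound 3 (0.35 log units; beyond the scatter) is known only as a lower bound because compound 1 sits at the limit of > 100000 nM in this assay, at which 2 of the 3 values shown sit.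

Compound 4, `O=Cc1cn(-c2ccc(O)cc2)nc1-c1cc(O)ccc1O`, has not yet been measured. It arises from compound 2 by the same kind of change, (formyl in place of 2-carboxyethenyl on an aromatic carbon); the surroundings are not identical, since here the changed carbon is next to the ring atom that bears a 2,5-dihydroxyphenyl group, whereas in compound 1 it is next to the ring atom that bears a 4-hydroxyphenyl group.

Compound 4 is expected to show a step of an at least 1.6-fold lower number from compound 2 to compound 4 (0.22 log units; that floor lies within the scatter) in this assay. Among the compounds with values here, this expectation rests on the single measured instance of the change, the step of an at least 2.2-fold lower number from compound 1 to compound 3 (0.35 log units; beyond the scatter), and on compound 2 sitting at the limit of > 100000 nM in this assay, at which 2 of the 3 values shown sit, which leaves its starting point open. Compound 4 is therefore estimated at 60000 nM, with a likely range from 20000 nM to 200000 nM.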

Compound 4, half-maximal inhibitory concentration: 43000 nM
Compound 4: the middle estimate sits 1.4-fold (0.14 log units) above what was measured, and the stated range covers the measured number.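

In this assay, putting formyl in place of 2-carboxyethenyl on the core bearing the 2,5-dihydroxyphenyl group gives an at least 2.3-fold lower number from compound 2 to compound 4 (0.36 log units; beyond the scatter), so the number falls on this core as well as on the core bearing the 4-hydroxyphenyl group. The change therefore carries over between these two cores in direction, although that rests on just these two pairs: the same change on two cores in this assay, an at least 2.2-fold lower number (0.35 log units; beyond the scatter) from compound 1 to compound 3 and an at least 2.3-fold lower number (0.36 log units; beyond the scatter) from compound 2 to compound 4; the limit leaves it open whether they differ What this does not show is how large either step truly is or whether the core alters its size, and the step between compound 1 and compound 2 likewise cannot be read, since the starting compounds give only limits and not numbers: the limit of > 100000 nM in this assay, at which 2 of the 4 values shown sit.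

The compounds shown leave open whether the lower number depends on formyl itself or simply on the loss of the longer 2-carboxyethenyl chain. A hydroxymethyl group, a nitrile or a carboxylic acid bonded directly to the same aromatic carbon could separate these two readings.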